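The source may hold more compounds than are shown below. What is called first, only, known or untested is meant among the compounds shown, and "the series" means these compounds.

Within the data shown here, compound 2, with the structure `CC(C)(C)c1ccc(Nc2nc3nonc3nc2O)cc1`, gives 0.6 h in an ADME assay on the whole organism (Mus musculus, strain C57BL/6) for metabolic stability, read by LC-MS, at a dose of 10 mg/kg by the oral route (on this read-out higher numbers stand for a longer-lived compound and lower numbers for a shorter-lived compound), and on the two numbers measured so far this is the highest, although its nearest neighbour, compound 1 with the structure `CCCCOc1ccc(Nc2nc3nonc3nc2O)cc1`, gives 0.3 h and the step of a 2.0-fold higher number from compound 1 to compound 2 (0.30 log units; within the scatter) lies within the scatter, so the two cannot be ordered. Compound 3, with the structure `CCCCc1ccc(Nc2nc3nonc3nc2O)cc1`, is the next compound to be examined in this assay. It differs from compound 2 in a single place: butyl in place of tert-butyl on an aromatic carbon. Among the measured compounds shown here, only one measured step bears on this change, the step from compound 1 to compound 2, which replaced butoxy with tert-butyl and came out within the scatter. For the measured compounds named here, that step touched a different pair of groups, so it gives only loose guidance; nothing among the measured compounds speaks for a step beyond the scatter in either direction for compound 3. Compound 3 is therefore expected to give about 0.45 h in this assay, within a range of 0.2 h to 1 h. This estimate corresponds to an expected step of a 1.3-fold lower number from compound 2 to compound 3 (0.12 log units; within the scatter).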

Compound 3, half-life: 0.7 h
The estimate for compound 3 lay 1.6-fold (0.19 log units) below the measured number; measured number inside the range.
By their numbers in this assay, from the lowest: compounds 1, 2 and 3 (each within the scatter of the next, the first and the last beyond it).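

Exchanging tert-butyl for butyl, two groups of the same four carbons, on an aromatic carbon para to a large group gives a 1.2-fold higher number from compound 2 to compound 3 (0.07 log units; within the scatter) in this assay, so the compounds shown do not separate these two groups at this position. Among these compounds, the same position now also yields the first step beyond the scatter: butyl in place of butoxy gives a 2.3-fold higher number from compound 1 to compound 3 (0.37 log units; beyond the scatter), a modest step, whereas tert-butyl in place of butoxy gave a 2.0-fold higher number from compound 1 to compound 2 (0.30 log units; within the scatter) and could not be read as a difference. Nothing available explains why butyl, but not tert-butyl, stands clear of butoxy, and no supporting measurement bears on this result.

Going by these compounds, what remains open is whether the modest separation from butoxy reflects a real feature of this position or only a small gap at the edge of the scatter, since it rests on a single pair of compounds. On these data alone, how a longer chain, an amine or a carboxylic acid at this place would read on the same core also stays unknown, as does whether any group could shift the half-life well beyond this narrow span.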